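Trimming the side chain of compound 2

The source may report more compounds than this note shows. Statements on the series, on what has been measured and on what is new or still open speak of the compounds shown alone.

Compound 1 `COCCNc1nc(F)c(-c2nn(Cc3ccc(C#N)cc3)c(=O)c3ccccc23)cc1Cl` gives > 100000 nM (a limit)
Compound 2 `COCCNc1ccc(-c2nn(Cc3ccc(C#N)cc3)c(=O)c3ccccc23)c(F)n1` gives > 100000 nM (a limit)
Compound 3 `N#Cc1ccc(Cn2nc(-c3cc(Cl)c(NC[C@@H](O)CO)nc3F)c3ccccc3c2=O)cc1` gives > 100000 nM (a limit)

In an ADME assay on HepG2 2.2.15 cells (Homo sapiens) for cytotoxicity, read by MTT assay, with a stated time of 8 days (a higher number here means that more compound is tolerated, a lower number that less compound is tolerated), compound 2 gives > 100000 nM as a limit and not a number. Compound 4 `CNc1ccc(-c2nn(Cc3ccc(C#N)cc3)c(=O)c3ccccc23)c(F)n1` differs from it in one place, where hydrogen in place of methoxymethyl on a saturated chain carbon bound to a nitrogen on an aromatic ring shortens 2-methoxyethyl to methyl. For the measured compounds named here, because a step that the two limits leave unreadable from compound 1 to compound 3 and a step that the two limits leave unreadable from compound 1 to compound 2 both lack a readable size, the sole guide is the limit of > 100000 nM in this assay, at which 3 of the 3 values shown sit, and nothing firmer. In this assay the expected step is a number no higher from compound 2 to compound 4 (the limit leaves the size open) and no step beyond the scatter, in either direction, is expected. For compound 4 the estimated value is 100000 nM with an expected range from 40000 nM to 300000 nM (quite possibly reported as a limit again).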

Compound 4, half-maximal cytotoxic concentration: > 100000 nM
Compound 4 was reported as a limit; the forecaster's own chance of this, stated with the estimate: 80%; the middle value sits exactly at the limit.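

For the compounds shown here, compound 2 and compound 4 both stand as limits in this assay, so no step between them can be read. The compounds shown leave open whether changing the side chain shifts the true value in this assay at all.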